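Swapping the thiazoline-type ring for its oxygen counterpart

A few compounds are considered here, and "the series" means these few. Any claim that something is new, unique, unknown or untested is made for them only; others in the source may bear on it.

Two cores carry the same side chain in this set, and both are compared after the same change. Compound 1 `Cc1ccc(C2CNN=C2S(=O)(=O)CC2=NCCS2)cc1` gives 39.8% in a functional assay, tested at 50 ug/mL; a higher number here means a stronger effect of the compound at the concentration tested, a lower number a weaker effect. Compound 3 `Cc1ccc(C2CNN=C2S(=O)(=O)CC2=NCCO2)cc1` carries the change a group of 5 heavy atoms (3 carbon, 1 nitrogen, 1 oxygen; one five-membered non-aromatic ring with 2 hetero atoms) in place of a group of 5 heavy atoms (3 carbon, 1 nitrogen, 1 sulfur; one five-membered non-aromatic ring with 2 hetero atoms), on a saturated chain carbon bound to a sulfonyl sulfur and gives 41.3% in this assay; the step of a number 1.5 percentage points higher from compound 1 to compound 3 (within the scatter) is within the scatter, so the two values cannot be told apart.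

Compound 2 `COc1ccc(-c2noc(-c3ccc(C)cc3)c2S(=O)(=O)CC2=NCCS2)cc1` rests on a different core; the difference between the two cores is not broken down here. In this assay compound 2 is reported as "not active" (no number reported), with no number given. Compound 4 `COc1ccc(-c2noc(-c3ccc(C)cc3)c2S(=O)(=O)CC2=NCCO2)cc1` is the partner of compound 2 after the change (a group of 5 heavy atoms (3 carbon, 1 nitrogen, 1 oxygen; one five-membered non-aromatic ring with 2 hetero atoms) in place of a group of 5 heavy atoms (3 carbon, 1 nitrogen, 1 sulfur; one five-membered non-aromatic ring with 2 hetero atoms), on a saturated chain carbon bound to a sulfonyl sulfur). The place of the change is the same in both pairs, so it is the same change made on a second core.

What is known gives little reason to expect a different outcome on the second core. The step from compound 1 to compound 3 showed no effect beyond the scatter, and compound 2 itself has no measurable effect, so compound 4 is expected to stay low as well. Compound 4 is expected to give about 8% in this assay, in a range from 0% to 22%, because a number 1.5 percentage points higher from compound 1 to compound 3 (within the scatter) was within the scatter on the other core.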

Compound 4, a percentage reported as activity, at one concentration (the size of the read-out at that concentration, not a potency): 70%
For compound 4 the middle estimate is 62 percentage points below the measured one, and the stated range ends below it.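

Within the data shown here, no step can be read from compound 2 to compound 4 in this assay: compound 2 is reported as "not active" (no number reported) and compound 4 gives 70%, so only one side of the pair has a number. No available evidence bears on this result. The compounds shown leave open how large the exchange of the sulfur-containing group for the oxygen-containing group is on this core.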